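Trifluoromethyl for fluoro on the anilide ring

The source may report more compounds than this note shows. Statements on the series, on what has been measured and on what is new or still open speak of the compounds shown alone.

Three compounds of the series carry a number or a limit in a functional assay (Cavia porcellus) with sulfonylurea receptors; K-ATP channels (Homo sapiens) as the target; a lower number here means a stronger inhibitor, a higher number a weaker inhibitor. Compound 1 `CC(O)(C(=O)Nc1ccc(S(=O)(=O)c2ccccc2)c(F)c1)C(F)(F)F` gives 1800 nM in this assay. Compound 2 `COc1ccccc1S(=O)(=O)c1ccc(NC(=O)C(C)(O)C(F)(F)F)cc1` gives 1600 nM in this assay, so that compound 1 and compound 2 sit within the scatter of each other. Compound 3 `COc1ccc(S(=O)(=O)c2ccc(NC(=O)C(C)(O)C(F)(F)F)cc2)cc1` gives only a limit of the assay, > 30000 nM. For the measured compounds named here, the one measured step is an at least 18-fold higher number from compound 2 to compound 3 (1.27 log units; beyond the scatter), and it rests on (the limit of > 30000 nM in this assay, at which 1 of the 3 values shown sits).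

Compound 4 `CC(O)(C(=O)Nc1ccc(S(=O)(=O)c2ccccc2)c(C(F)(F)F)c1)C(F)(F)F` differs from compound 1 by trifluoromethyl in place of fluoro on an aromatic carbon. Going by the values given here, the measured step concerns the methoxyphenyl on the sulfonyl sulfur, not the ring of the anilide that carries the fluoro, so no measured step bears directly on this change. Without a comparable measured step, no step beyond the scatter is expected, and the value of compound 4 is estimated close to that of compound 1, with a wide range; this expectation means a 1.1-fold higher number from compound 1 to compound 4 (0.05 log units; within the scatter). The estimate for compound 4 in this assay is 2000 nM, between 600 nM and 7000 nM.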

Compound 4, half-maximal inhibitory concentration: > 30000 nM
Compound 4: only a limit was reported; the forecaster's own chance of this, stated with the estimate: 10%; middle value at least 15-fold (1.17 log units) from the limit.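

Trifluoromethyl is not tolerated in place of fluoro at this aromatic carbon: this assay shows an at least 16-fold higher number from compound 1 to compound 4 (1.22 log units; beyond the scatter). Compound 4 gives > 30000 nM, which is a limit of the assay, so the size of the step is bounded on one side only: the limit of > 30000 nM in this assay, at which 2 of the 4 values shown sit.

For the compounds shown here, the one earlier step, an at least 18-fold higher number from compound 2 to compound 3 (1.27 log units; beyond the scatter), concerned the methoxyphenyl on the sulfonyl sulfur, whereas this one shows that a single change on the anilide ring can also carry the number to the limit.

Going by these compounds, whether methyl, chloro or a nitrile at this carbon would keep the number of compound 1 stays open, as does the true value of compound 4. Also open, on these data alone, is whether the same change has the same outcome with 2-methoxyphenyl on the sulfonyl sulfur.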